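The compounds below may be only part of what the source reports. "The series", "measured", "known", "first", "only" and "open" are said of these compounds alone.

Measured so far:
compound 1, `Cc1nc(N(C)C(=O)NC(=O)c2c(F)cccc2F)sc1C(=O)N/N=C/c1cccc(C(F)(F)F)c1`: 31.6 ug/mL
compound 2, `Cc1nc(N(C)C(=O)NC(=O)c2c(F)cccc2F)sc1C(=O)N/N=C/c1ccccc1F`: > 100 ug/mL

In a functional assay on HepG2 cells (Homo sapiens) for inhibition, read by MTT assay, with a stated time of 72 h (on this read-out lower numbers stand for stronger inhibition and higher numbers for weaker inhibition), compound 1 gives 31.6 ug/mL. Compound 2, in turn, gives only a limit in this assay, (the limit of > 100 ug/mL in this assay, at which 1 of the 2 values shown sits), so no number is known for it and it stands at the weak end of what has been seen. Among the compounds with values here, the one measured step, an at least 3.1-fold higher number from compound 1 to compound 2 (0.50 log units; beyond the scatter), shows that exchanging the aromatic group on the carbon with a double bond to nitrogen can shift inhibition at least modestly.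

Compound 3, `Cc1nc(N(C)C(=O)NC(=O)c2c(F)cccc2F)sc1C(=O)N/N=C/c1ccc(Cl)cc1Cl`, has not been measured. Its change from compound 2 is 2,4-dichlorophenyl in place of 2-fluorophenyl on a carbon with a double bond to nitrogen. Within the data shown here, that measured step is the only guide, and it speaks only for that aromatic exchange; nothing measured tells where 2,4-dichlorophenyl falls. For compound 3 the estimate in this assay is 60 ug/mL, ranging from 20 ug/mL to 200 ug/mL. This expected step, an at least 1.6-fold lower number from compound 2 to compound 3 (0.22 log units; that floor lies within the scatter), leans toward stronger inhibition but with wide uncertainty, since compound 2 is itself only a limit.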

Compound 3, half-maximal inhibitory concentration: 70 ug/mL
Compound 3: middle estimate off by 1.2-fold (0.07 log units), on the low side, within the range that was stated.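

In this assay, compound 3 shows that a second group at this carbon with a double bond to nitrogen, 2,4-dichlorophenyl, gives a real number, and that this number is weaker than the one for 3-(trifluoromethyl)phenyl, with a 2.2-fold higher number from compound 1 to compound 3 (0.35 log units; beyond the scatter). Against 2-fluorophenyl the change reads as an at least 1.4-fold lower number from compound 2 to compound 3 (0.15 log units; that floor lies within the scatter), so a true gain over that group is not established. Compound 2 remains only a limit: the limit of > 100 ug/mL in this assay, at which 1 of the 3 values shown sits.

The compounds shown leave open how an unsubstituted phenyl ring, or one carrying a single chlorine, would read at this carbon, and so whether both chlorines of compound 3 matter. From the compounds shown here alone, a phenyl ring bearing a methoxy group, a dimethylamino group or a carboxylic acid also remains unexplored here.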